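The source may hold more compounds than are shown below. What is called first, only, known or untested is meant among the compounds shown, and "the series" means these compounds.

Measured compounds in a functional assay on HepG2 cells (Homo sapiens) for antiproliferative activity, read by MTT assay, with a stated time of 48 h; on this read-out higher numbers stand for weaker inhibition and lower numbers for stronger inhibition:
Compound 1 `N#CC1=C(N)Oc2c(c3nc4ccccc4nc3c3ccccc23)C12C(=O)N(Cc1cnnn1-c1ccc(S(N)(=O)=O)cc1)c1ccccc12` gives 42200 nM.
Compound 2 `N#CC1=C(N)Oc2c(c3nc4ccccc4nc3c3ccccc23)C12C(=O)N(Cc1cnnn1-c1cccc(S(N)(=O)=O)c1)c1ccccc12` gives 21500 nM.
Compound 3 `Cc1cc(C)cc(-n2nncc2CN2C(=O)C3(C(C#N)=C(N)Oc4c3c3nc5ccccc5nc3c3ccccc43)c3ccccc32)c1` gives only a limit of the assay, > 50000 nM.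

Compound 3 thus stands at the weak end of the numbers shown; the assay reports no number for it, and that limit of > 50000 nM in this assay, at which 1 of the 3 values shown sits, is where one of the three values sits. Compound 4 `Cc1ccc(-n2nncc2CN2C(=O)C3(C(C#N)=C(N)Oc4c3c3nc5ccccc5nc3c3ccccc43)c3ccccc32)c(C)c1` differs from compound 3 in one place: 2,4-dimethylphenyl in place of 3,5-dimethylphenyl on an aromatic nitrogen. The two compounds have the same atoms, joined differently.

For the measured compounds named here, the only measured step of the same kind, a shift of substituents around the phenyl ring on the triazole nitrogen, is a 2.0-fold lower number from compound 1 to compound 2 (0.29 log units; within the scatter), and it stayed within the scatter. The other two steps, an at least 1.1-fold higher number from compound 1 to compound 3 (0.07 log units; that floor lies within the scatter) and an at least 2.3-fold higher number from compound 2 to compound 3 (0.36 log units; beyond the scatter), exchange the sulfamoylphenyl for the dimethylphenyl and so bear less directly on the move from compound 3 to compound 4; they mainly show that compound 3 sits at the limit. On this basis no step beyond the scatter is expected in this assay, and compound 4 is likely to remain at or near the limit of the assay, that is the step expected is a step that the limit leaves unreadable from compound 3 to compound 4. The estimate for compound 4 is 60000 nM, with a range from 25000 nM to 150000 nM.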

Compound 4, half-maximal inhibitory concentration: > 50000 nM
Compound 4 was reported as a limit (the forecaster's own chance of this, stated with the estimate: 70%); the middle value is on the limit's open side.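

In this assay compound 4 gives > 50000 nM, which is a limit of the assay and not a number, so a second dimethylphenyl pattern on the aromatic nitrogen, 2,4-dimethylphenyl as well as 3,5-dimethylphenyl, ends at the weak end of the values shown. Placing 2,4-dimethylphenyl where the sulfamoylphenyl groups stood gives an at least 2.3-fold higher number from compound 2 to compound 4 (0.36 log units; beyond the scatter) and an at least 1.1-fold higher number from compound 1 to compound 4 (0.07 log units; that floor lies within the scatter), so only the comparison with the 3-sulfamoylphenyl compound clears the scatter, and the comparison with the 4-sulfamoylphenyl compound has a floor that does not. The step between compound 3 and compound 4 cannot be read, because both compounds rest on the same limit: the limit of > 50000 nM in this assay, at which 2 of the 4 values shown sit.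

Going by these compounds, it therefore remains open whether moving the two methyl groups around the phenyl ring changes anything in this assay, and how far either dimethylphenyl compound lies beyond the limit. The compounds shown also leave open how a phenyl ring carrying an amine or a carboxylic acid would read at this position, and whether either would come closer to the sulfamoylphenyl compounds or pass them.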